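The compounds below may be only part of what the source reports. "The series", "measured", "known", "first", "only" and "open" are said of these compounds alone.

In an ADME assay on microsomes from liver (Homo sapiens) for metabolic stability, read by LC-MS, with a stated time of 10 min (on this read-out higher numbers stand for a more stable compound and lower numbers for a less stable compound), compound 1 `c1cnc2c(c1)CCC[C@@H]2N(CC1CC1)C[C@H]1Cc2c(cccc2N2CCNCC2)CN1` gives 82.1% as the higher of the two numbers available. Compound 3 `CN(C[C@H]1Cc2c(cccc2N2CCN(C3CC3)CC2)CN1)[C@H]1CCCc2cccnc21` gives 15.5% which is lower beyond the scatter, though it differs from compound 1 in more than one place. For compound 2 `Cc1cnc(CN(C)C[C@H]2Cc3c(cccc3N3CCNCC3)CN2)c(C)c1` the entry reads "not determined" (no result reported) and offers no number. Compound 4 `CCN(C[C@H]1Cc2c(cccc2N2CCNCC2)CN1)[C@H]1CCCc2cccnc21` is still unmeasured and departs from compound 1 by a single change. The counted difference methyl in place of cyclopropyl on a saturated chain carbon bound to an amine nitrogen is methyl in place of cyclopropyl on a saturated chain carbon bound to an amine nitrogen. Among the measured compounds shown here, no measured pair covers this change, so the expectation rests on compound 1 at 82.1% alone. The expected a number 4.1 percentage points lower from compound 1 to compound 4 (within the scatter) in this assay is a small fall, not beyond the scatter. For compound 4 the estimated value is 78% with a range from 58% to 93% expected.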

Compound 4, percent of the compound remaining: 79.1%
Beside the measured number, compound 4's estimate is 1.1 percentage points below it; measured number inside the range.
By their numbers in this assay, from the lowest: compound 3; then compounds 4 and 1 (each within the scatter of the next).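

Cyclopropylmethyl to ethyl, read as methyl in place of cyclopropyl on a saturated chain carbon bound to an amine nitrogen, gives a number 3 percentage points lower from compound 1 to compound 4 (within the scatter) in this assay. Among the compounds shown here, this is the first single-place step at this position. With the piperazine-bearing core of compound 1 held constant, the three-membered ring at this place is not required for a number within the scatter of compound 1.

As far as these compounds go, whether a longer chain such as n-propyl, or an ethyl chain ending in a hydroxyl group, would stay within that scatter remains open. No measured evidence offers a cause for this step.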